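This account rests on a few compounds, and the source may have more. Where it says the series, first, only, none or still open, it means among the compounds named here.

Compound 1 `Cc1ccc([N+](=O)[O-])cc1C(=O)N(C)/N=C/c1cnn2ccc(C#N)cc12` — > 20000 nM in a functional assay on NZB5 cells (Homo sapiens) for inhibition, read by thymidine incorporation, with a stated time of 5 days; a lower number here means a stronger inhibitor, a higher number a weaker inhibitor
Compound 2 `Cc1ccc([N+](=O)[O-])cc1CN(C)/N=C/c1cnn2ccc(C#N)cc12` — 1700 nM in this assay

Compound 1 stands at the edge of what this assay reports: its value is a limit, not a number, namely (the limit of > 20000 nM in this assay, at which 1 of the 2 values shown sits). Compound 3 `CN(/N=C/c1cnn2ccc(C#N)cc12)C(=O)c1cccc([N+](=O)[O-])c1` differs from compound 1 in one place, (hydrogen in place of methyl on an aromatic carbon). Going by the values given here, no measured step shows the effect of this change, and compound 1 itself sits at a limit. No step beyond the scatter is expected in this assay. The expected step from compound 1 to compound 3 is a number no higher from compound 1 to compound 3 (the limit leaves the size open). Compound 3 is expected to give about 20000 nM, within 5000 nM to 60000 nM, most likely again reported only as a limit.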

Compound 3, half-maximal inhibitory concentration: 1800 nM
Compound 3: the middle estimate sits 11-fold (1.05 log units) above what was measured, outside the stated range (below it).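

In this assay, the change of hydrogen in place of methyl on this aromatic carbon gives an at least 11-fold lower number from compound 1 to compound 3 (1.04 log units; beyond the scatter). Going by these compounds alone, this is the first sign that this position, ortho to a large group and para to a nitro group, matters to the read-out, and that a single methyl here can separate a measurable inhibitor from one that is not. The value of compound 1 is a limit, not a number: the limit of > 20000 nM in this assay, at which 1 of the 3 values shown sits.

Going by these compounds, the full size of the step stays open. So does whether an ethyl group, a chlorine atom or a methoxy group on this carbon would behave like hydrogen or like methyl.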